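The compounds below may be only part of what the source reports. "The series", "measured", "known", "first", "only" and "open" are said of these compounds alone.

Compound 3 `CNC(=O)CN1CC[C@H](n2c(Nc3ccc(F)cc3)nc3cnc(Nc4ccc(N5CCN(C)CC5)cc4)nc32)C1` gives 1520 nM in a functional assay on HCC827 cells (Homo sapiens) for antiproliferative activity, read by MTT assay, with a stated time of 72 h (on this read-out higher numbers stand for weaker inhibition and lower numbers for stronger inhibition), the highest of the three measured numbers. Compound 1 `CN1CCN(c2ccc(Nc3ncc4nc(Nc5ccc(F)cc5)n([C@H]5CCCN(S(=O)(=O)C6CC6)C5)c4n3)cc2)CC1` gives 8.6 nM, and compound 2 `CN1CCN(c2ccc(Nc3ncc4nc(Nc5ccc(F)cc5)n([C@H]5CCN(C(=O)CO)C5)c4n3)cc2)CC1` gives 380 nM. Compound 4 `CN1CCN(c2ccc(Nc3ncc4nc(Nc5ccc(F)cc5)n([C@H]5CCCN(C(=O)CO)C5)c4n3)cc2)CC1` has not yet been measured. It differs from compound 3 by 1-((hydroxymethyl)carbonyl)piperidin-3-yl in place of 1-((methylcarbamoyl)methyl)pyrrolidin-3-yl on an aromatic nitrogen.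

For the measured compounds named here, two measured steps bear on this. The step of a 4.0-fold higher number from compound 2 to compound 3 (0.60 log units; beyond the scatter) shows that swapping the amide group alone on the pyrrolidine moved the number by a modest amount; compound 4 reverses that swap. Going by the values given here, the step of a 44-fold higher number from compound 1 to compound 2 (1.65 log units; beyond the scatter) shows a large change when both the ring size and the amide group were altered together, but no measured pair shows the ring change on its own. Compound 4 carries the same amide as compound 2 on the larger ring of compound 1, so its number is expected to land near that of compound 2, perhaps somewhat lower. The expected step is a 7.6-fold lower number from compound 3 to compound 4 (0.88 log units; beyond the scatter), a decrease beyond the scatter. The estimate for compound 4 is 200 nM, within the range 60 nM to 700 nM.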

Compound 4, half-maximal inhibitory concentration: 1.8 nM
Beside the measured number, compound 4's estimate is 110-fold (2.05 log units) above it; measured number below the stated range.
By their numbers in this assay, from the lowest: compound 4; then compound 1; then compound 2; then compound 3.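

For the compounds shown here, with (hydroxymethyl)carbonyl kept on the ring nitrogen, changing only pyrrolidin-3-yl to piperidin-3-yl gives a 210-fold lower number from compound 2 to compound 4 (2.32 log units; beyond the scatter) in this assay, so ring size at this aromatic nitrogen has a large effect on its own, which no earlier pair could isolate. On the six-membered ring, (hydroxymethyl)carbonyl in place of cyclopropylsulfonyl gives a 4.8-fold lower number from compound 1 to compound 4 (0.68 log units; beyond the scatter), showing that the group on the ring nitrogen still matters, though much less in this pair. The largest step, an 840-fold lower number from compound 3 to compound 4 (2.93 log units; beyond the scatter), changes both the ring and its substituent, so it cannot be divided between them.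

Still open, from the compounds shown here alone, is how (methylcarbamoyl)methyl behaves on the piperidine ring, and whether a seven-membered azepane ring or a longer chain such as 3-hydroxypropanoyl would keep the low number. No evidence here explains the effect of the ring change.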